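Cytotoxicity on Vero Cells: Propoxymethyl in Place of Butylamino

The source may report more compounds than this note shows. Statements on the series, on what has been measured and on what is new or still open speak of the compounds shown alone.

Compound 1 `CCCNC(=O)Nc1cc2nc(C3CCCCC3)[nH]c2cc1N(CC)CC` reaches only the assay limit > 100 ug/mL in an ADME assay on Vero cells (Chlorocebus sabaeus) for cytotoxicity, read by resazurin assay, with a stated time of 3 days; a lower number here means a stronger inhibitor, a higher number a weaker inhibitor.
Compound 2 `CCN(CC)c1cc2[nH]c(C3CCCCC3)nc2cc1NC(=O)c1ccc(F)cc1` likewise sits at the limit > 100 ug/mL in this assay.
Compound 3 `CCCCNC(=O)Nc1cc2nc(C3CCCCC3)[nH]c2cc1N(CC)CC` also stops at the limit > 100 ug/mL in this assay.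

Compound 3 therefore stands where every measured compound stands, at the limit of > 100 ug/mL in this assay, at which 3 of the 3 values shown sit. The three steps among them, a step that the two limits leave unreadable from compound 1 to compound 2, a step that the two limits leave unreadable from compound 1 to compound 3 and a step that the two limits leave unreadable from compound 2 to compound 3, are each hidden by the limit. Compound 4 `CCCOCC(=O)Nc1cc2nc(C3CCCCC3)[nH]c2cc1N(CC)CC` differs from compound 3 by propoxymethyl in place of butylamino on a carbonyl carbon. No measured step can be read for a change of this kind, so nothing points to a shift in either direction beyond the scatter. Compound 4 is expected to behave as its neighbours, with a number no higher from compound 3 to compound 4 (the limit leaves the size open) being a null step, and its estimate is 100 ug/mL, between 40 ug/mL and 200 ug/mL.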

Compound 4, half-maximal inhibitory concentration: > 100 ug/mL
Compound 4: no number, only a limit (the forecaster's own chance of this, stated with the estimate: 85%); the middle value lies on the limit itself.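

No step can be read among compound 1, compound 2, compound 3 and compound 4 in this assay, since each gives only a limit: the limit of > 100 ug/mL in this assay, at which 4 of the 4 values shown sit.

The compounds shown leave open whether any change on the carbonyl carbon shifts the true value at all.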